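Aryl-to-arylamino exchange on a shared oxadiazole-free core description

The compounds below may be only part of what the source reports. "The series", "measured", "known", "first", "only" and "open" are said of these compounds alone.

Measured so far in a functional assay on the whole organism (strain Wistar) for inhibition, with Rattus norvegicus as the target, read by paw edema, with a stated time of 4 h, at a dose of 10 mg/kg by the oral route; on this read-out higher numbers stand for more inhibition at the one dose given (going by the name of the read-out) and lower numbers for less inhibition:
Compound 1, `Clc1ccc(-c2nnc(COc3ccc(-c4ccccc4)cc3)o2)cc1`, gives 77.3%.
Compound 2, `CC(C)Cc1ccc(C(C)c2nnc(COc3ccc(-c4ccccc4)cc3)o2)cc1`, gives 79.5%.

Compound 1 holds the lower of the two values in this assay, though the value of compound 2 sits within the scatter of it, so the two compounds are not told apart on this read-out. Compound 3, `Fc1ccc(Nc2nnc(COc3ccc(-c4ccccc4)cc3)o2)cc1`, has not yet been measured. It differs from compound 1 in one place: (4-fluorophenyl)amino in place of 4-chlorophenyl on an aromatic carbon. Among the measured compounds shown here, no measured pair shows this kind of change, so its effect in this assay is unknown from the numbers at hand. A moderate step is anticipated, most likely downward from compound 1 or of a size no larger than the scatter. Compound 3 is therefore expected to give 68%, in a range from 50% to 84%, an estimated step of a number 9.3 percentage points lower from compound 1 to compound 3 (within the scatter).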

Compound 3, a percentage reported as inhibition, in the whole organism at one dose (the size of the read-out at that dose, not a potency): 52.3%
Beside the measured number, compound 3's estimate is 15.7 percentage points above it; measured number inside the range.
By their numbers in this assay, from the lowest: compound 3; then compounds 1 and 2 (each within the scatter of the next).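

In this assay, placing (4-fluorophenyl)amino instead of 4-chlorophenyl on the aromatic carbon next to the ring nitrogen and next to the ring oxygen gives a number 25 percentage points lower from compound 1 to compound 3 (beyond the scatter), so the read-out does respond to what this position carries. Among the compounds shown here, the earlier compounds could not show this, as the only two values then at hand lay within the scatter of each other. This single change swaps chlorine for fluorine and adds an amino link with its hydrogen-bond donor, and nothing measured here says why the number falls.

Going by these compounds, it remains open what (4-chlorophenyl)amino or plain 4-fluorophenyl would give on this carbon, which would separate the amino link from the halogen exchange. On these data alone, the effect of a carboxylic acid or a morpholine at this position also remains open.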